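Swapping the Pyrazole Nitrogen Substituent in Compound 3

This account rests on a few compounds, and the source may have more. Where it says the series, first, only, none or still open, it means among the compounds named here.

Compound 1 `CNC(=O)N1CCCc2ccc(NC(=O)c3ccc(-c4ccn(S(C)(=O)=O)n4)cc3)cc21`: 57.2%
Compound 2 `CNC(=O)N1CCCc2ccc(NC(=O)c3ccc(-c4ccccn4)cc3)cc21`: 79.2%
Compound 3 `CNC(=O)N1CCCc2ccc(NC(=O)c3ccc(-c4cnn(S(C)(=O)=O)c4)cc3)cc21`: 40.2%

All three share the same core and differ only in the ring attached to the benzamide. In a functional assay on MV4-11 cells (Homo sapiens) for antiproliferative activity, with a stated time of 6 days, tested at 6.25 uM (a higher number here means a stronger effect of the compound at the concentration tested, a lower number a weaker effect), two steps end at compound 3: the step of a number 17 percentage points lower from compound 1 to compound 3 (beyond the scatter) and the step of a number 39 percentage points lower from compound 2 to compound 3 (beyond the scatter). Compound 3 therefore stands lowest of the three numbers, and both gaps lie beyond the scatter.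

Compound 4 `CNC(=O)N1CCCc2ccc(NC(=O)c3ccc(-c4cnn(C(C)=O)c4)cc3)cc21` is the next compound to be measured. It differs from compound 3 in one place: acetyl in place of methylsulfonyl on an aromatic nitrogen. Among the compounds with values here, none of the measured steps touches this group. The step of a number 22 percentage points higher from compound 1 to compound 2 (beyond the scatter) exchanges the whole ring, and the step between compound 1 and compound 3 moves the point at which the same ring is attached; the group on the ring nitrogen stays the same throughout. There is thus no direct guide, and a small change is expected, likely within the scatter or only slightly beyond it. Compound 4 is estimated at 42% in this assay, within a range of 25% to 60%. This estimate means an expected step of a number 1.8 percentage points higher from compound 3 to compound 4 (within the scatter).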

Compound 4, a percentage reported as inhibition, at one concentration (the size of the read-out at that concentration, not a potency): 83.8%
Compound 4: the middle estimate sits 41.8 percentage points below what was measured; the measured number lies above the stated range.
By their numbers in this assay, from the lowest: compound 3; then compound 1; then compounds 2 and 4 (each within the scatter of the next).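

In this assay, within the data shown here, the group on the ring nitrogen proves to matter a great deal: with acetyl in place of methylsulfonyl and nothing else changed, the result is a number 43.6 percentage points higher from compound 3 to compound 4 (beyond the scatter), whereas the earlier steps only exchanged the ring or moved its point of attachment. This one exchange also changes how the pyrazole ring compares with the other rings: the step from pyridin-2-yl is a number 4.6 percentage points higher from compound 2 to compound 4 (within the scatter), and the step from the 3-linked methylsulfonyl ring is a number 26.6 percentage points higher from compound 1 to compound 4 (beyond the scatter). Nothing available here explains why this exchange has so large an effect.

The compounds shown leave open how this ring nitrogen responds to other groups, such as a plain methyl, a longer propanoyl chain or a dimethylcarbamoyl group. From the compounds shown here alone, it is also open whether acetyl would have a similar effect on the ring of compound 1, attached at its 3-position.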